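Swapping one ring on compound 1

A few compounds are considered here, and "the series" means these few. Any claim that something is new, unique, unknown or untested is made for them only; others in the source may bear on it.

Values from an ADME assay on microsomes from liver (Homo sapiens) for metabolic stability, read by LC-MS, using NADPH, with stated times of 5 min and 30 min, tested at 1 uM (a lower number here means slower removal, a higher number faster removal of the compound), are as follows
compound 1 `Cc1nccn1-c1cnc(NCc2c(F)ccc3c2CCO3)c2cn[nH]c(=O)c12` gives 8 mL.min-1.g-1
compound 2 `CN(C)Cc1ccc2c(c1)CN(c1cnc(NCc3c(F)ccc4c3CCO4)n3cnnc13)C2=O` gives 19 mL.min-1.g-1

Compound 1 has the lower number of the two, and the gap up to compound 2 lies beyond the usual scatter. Compound 3 `Cc1cc(-c2cnc(NCc3c(F)ccc4c3CCO4)c3cn[nH]c(=O)c23)n(C)n1` carries 1,3-dimethyl-1H-pyrazol-5-yl in place of 2-methyl-1H-imidazol-1-yl on an aromatic carbon. Among the compounds with values here, no measured pair shows this kind of change, which leaves the forecast loose. A small rise in this assay is expected, an estimated 1.5-fold higher number from compound 1 to compound 3 (0.18 log units; within the scatter) that stays within the scatter. The estimated value for compound 3 is 12 mL.min-1.g-1 (expected range 5 mL.min-1.g-1 to 26 mL.min-1.g-1).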

Compound 3, intrinsic clearance in microsomes: 24 mL.min-1.g-1
Compound 3: the middle estimate sits 2.0-fold (0.30 log units) below what was measured; low and high end bracket the measured number.
By their numbers in this assay, from the lowest: compound 1; then compounds 2 and 3 (each within the scatter of the next).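

On this aromatic carbon of the shared core, putting 1,3-dimethyl-1H-pyrazol-5-yl in place of 2-methyl-1H-imidazol-1-yl gives a 3.0-fold higher number from compound 1 to compound 3 (0.48 log units; beyond the scatter) in this assay. The group at this position therefore matters for the read-out, even though both groups have one five-membered aromatic ring with 2 hetero atoms and no net charge. Nothing available explains why this swap speeds removal.

The compounds shown cannot separate the effect of the changed ring from that of the added carbon. On these data alone, how an amine or a carboxylic acid on this carbon would read also remains open.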